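The source may report more compounds than this note shows. Statements on the series, on what has been measured and on what is new or still open speak of the compounds shown alone.

In a physicochemical assay for solubility, in phosphate buffer, with a stated time of 18 h, at pH 7 (on this read-out lower numbers stand for lower solubility and higher numbers for higher solubility), compound 1 `CC(C)CN1C(=O)c2ccccc2[C@H](C(=O)Nc2ccc(F)c(C#N)c2)[C@H]1c1ccoc1` gives 15000 nM and compound 2 `CC(C)CN1C(=O)c2ccccc2[C@H](C(=O)Nc2ccc(F)c(C#N)c2)[C@H]1c1ccco1` gives 13000 nM on the shared core. Between these two furans the swap amounts to a 1.2-fold lower number from compound 1 to compound 2 (0.06 log units; within the scatter) and separates nothing. Compound 3 `CC(C)CN1C(=O)c2ccccc2[C@H](C(=O)Nc2ccc(F)c(C#N)c2)[C@H]1c1cccnc1` stands highest of the three at 55000 nM with both furans clearly lower.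

Next is compound 4 `CC(C)CN1C(=O)c2ccccc2[C@H](C(=O)Nc2ccc(F)c(C#N)c2)[C@H]1c1ccnnc1` with pyridazin-4-yl in place of pyridin-3-yl on a saturated ring carbon and the rest of the structure unchanged. Among the compounds with values here, no measured pair exchanges one six-membered aromatic ring for another, so the guidance is indirect. The nearest evidence is the pair of modest steps into the pyridine, a 3.7-fold higher number from compound 1 to compound 3 (0.56 log units; beyond the scatter) and a 4.2-fold higher number from compound 2 to compound 3 (0.63 log units; beyond the scatter) in size, both upward. A further upward move of similar modest size is expected, though with wide uncertainty: a 2.4-fold higher number from compound 3 to compound 4 (0.37 log units; beyond the scatter) is the step estimated here. The estimate for compound 4 is 130000 nM (expected range 50000 nM to 320000 nM).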

Compound 4, solubility: 28000 nM
Beside the measured number, compound 4's estimate is 4.6-fold (0.67 log units) above it; the measured number lies below the stated range.
By their numbers in this assay, from the lowest: compounds 2, 1, 4 and 3 (each within the scatter of the next, the first and the last beyond it).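

In this assay, the second ring nitrogen of pyridazin-4-yl gives no separation from pyridin-3-yl at this saturated ring carbon: the step is a 2.0-fold lower number from compound 3 to compound 4 (0.29 log units; within the scatter). Against the furans the result splits, with a 2.2-fold higher number from compound 2 to compound 4 (0.33 log units; beyond the scatter) but a 1.9-fold higher number from compound 1 to compound 4 (0.27 log units; within the scatter), so among the six-membered aromatic rings shown, only pyridin-3-yl stands clear of both furans. Nothing measured on these compounds accounts for these values.

Still open, going by these compounds, is how a pyrimidin-5-yl group or a saturated ring carrying an amine would read at this carbon. Also open, on these data alone, is whether the steps seen here hold when the isobutyl group is replaced by a longer chain.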